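A few compounds are considered here, and "the series" means these few. Any claim that something is new, unique, unknown or untested is made for them only; others in the source may bear on it.

- compound 1 `O=C1c2c[n+]([O-])c3ccccc3c2C(=O)c2c1c1ccccc1n2Cc1cn(CC(O)CO)nn1`: 440 nM
- compound 2 `CC1(C)OC[C@@H](Cn2cc(Cn3c4c(c5ccccc53)C(=O)c3c[n+]([O-])c5ccccc5c3C4=O)nn2)O1`: 450 nM

Both numbers come from a functional assay on A-375 cells (Homo sapiens) for cytotoxicity, read by MTT assay, with a stated time of 72 h; on this read-out higher numbers stand for weaker inhibition and lower numbers for stronger inhibition. Among the measured compounds shown here, with only two compounds measured, compound 2 cannot be told apart from compound 1: the gap between them, a 1.0-fold higher number from compound 1 to compound 2 (0.01 log units; within the scatter), is no larger than repeat measurements would give.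

Compound 3 `O=C1c2c[n+]([O-])c3ccccc3c2C(=O)c2c1c1ccccc1n2Cc1cn([C@H]2C[C@H](O)[C@@H](CO)O2)nn1` keeps the shared core but carries a different group on an aromatic nitrogen: 4-hydroxy-5-(hydroxymethyl)oxolan-2-yl in place of (2,2-dimethyl-1,3-dioxolan-4-yl)methyl on an aromatic nitrogen. In short, 4-hydroxy-5-(hydroxymethyl)oxolan-2-yl replaces (2,2-dimethyl-1,3-dioxolan-4-yl)methyl.

For the measured compounds named here, only one measured step bears on this change, a 1.0-fold higher number from compound 1 to compound 2 (0.01 log units; within the scatter). There, 2,2-dimethyl-1,3-dioxolan-4-yl took the place of 1,2-dihydroxyethyl in the same part of the molecule, and the number did not move beyond the scatter. Going by the values given here, that step is a single example and a smaller change, and no measured compound has its ring directly on the aromatic nitrogen. A shift in this assay beyond the scatter is therefore not expected, in either direction, but the range must stay wide.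

The expected change is a 1.1-fold higher number from compound 2 to compound 3 (0.05 log units; within the scatter). Compound 3 is estimated at 500 nM, with an expected range of 200 nM to 1250 nM.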

Compound 3, half-maximal inhibitory concentration: 390 nM
For compound 3 the middle estimate is 1.3-fold (0.11 log units) above the measured one; measured number inside the range.
By their numbers in this assay, from the lowest: compounds 3, 1 and 2 (each within the scatter of the next).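

In this assay, 4-hydroxy-5-(hydroxymethyl)oxolan-2-yl on the aromatic nitrogen gives a 1.2-fold lower number from compound 2 to compound 3 (0.06 log units; within the scatter) when it replaces (2,2-dimethyl-1,3-dioxolan-4-yl)methyl and a 1.1-fold lower number from compound 1 to compound 3 (0.05 log units; within the scatter) when it replaces 2,3-dihydroxypropyl. The earlier step changed only the far end of the side group, whereas these steps show that a five-membered non-aromatic ring can stand on the aromatic nitrogen itself, and that compound 3, with its three defined stereocentres, still cannot be told apart from the other two compounds. Nothing available here explains why the numbers stay so close.

Going by these compounds, all three groups carry only carbon and oxygen atoms, so it remains open whether an amine, a carboxylic acid or a longer chain on this nitrogen would move the number beyond the scatter. The compounds shown also leave open whether the ring of compound 3 would give a similar number with its three stereocentres in a different arrangement, or in cells other than those of this single assay.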